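A Chloro-to-Hydroxy Step Repeated on a Second Core

The source may report more compounds than this note shows. Statements on the series, on what has been measured and on what is new or still open speak of the compounds shown alone.

Compound 1, `N#Cc1c(-c2ccc(Cl)cc2)nc(SCC(=O)Nn2c(COc3ccc(Cl)cc3Cl)nc3ccccc3c2=O)n(Cc2ccccc2)c1=O`, gives 61.5%.
Compound 2, `N#Cc1c(-c2ccc(O)cc2)nc(SCC(=O)Nn2c(COc3ccc(Cl)cc3Cl)nc3ccccc3c2=O)n(Cc2ccccc2)c1=O`, gives 51.9%.
Compound 3, `N#Cc1c(Nc2ccc(Cl)cc2)nc(SCC(=O)Nn2c(COc3ccc(Cl)cc3Cl)nc3ccccc3c2=O)nc1-c1ccc(Cl)cc1`, gives 46.2%.

The values above come from a functional assay on the whole organism (strain albino) for inhibition, with Rattus norvegicus as the target, read by paw edema, with stated times of 1 h and 0.5 h, at a dose of 100 mg/kg by the oral route; on this read-out lower numbers stand for less inhibition and higher numbers for more inhibition at the one dose given (going by the name of the read-out). Compound 1 and compound 2 share a core and differ only by hydroxy in place of chloro on an aromatic carbon; this change gave a number 9.6 percentage points lower from compound 1 to compound 2 (within the scatter). Compound 3 rests on a different core; the difference between the two cores is not broken down here. Compound 4, `N#Cc1c(Nc2ccc(O)cc2)nc(SCC(=O)Nn2c(COc3ccc(Cl)cc3Cl)nc3ccccc3c2=O)nc1-c1ccc(Cl)cc1`, is not yet measured and differs from compound 3 by hydroxy in place of chloro on an aromatic carbon, the same change as from compound 1 to compound 2 at the same kind of place. Because a number 9.6 percentage points lower from compound 1 to compound 2 (within the scatter) was within the scatter, the expected step is a number 8.2 percentage points lower from compound 3 to compound 4 (within the scatter), a small one. Compound 4 is therefore estimated at 38%, between 25% and 50%.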

Compound 4, a percentage reported as inhibition, in the whole organism at one dose (the size of the read-out at that dose, not a potency): 71.2%
The estimate for compound 4 lay 33.2 percentage points below the measured number; the measured number lies above the stated range.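

In this assay the exchange of chloro for hydroxy did not carry over from one core to the other, giving a number 25 percentage points higher from compound 3 to compound 4 (beyond the scatter). The two steps disagree, so the earlier step did not predict the later one: the same change on two cores in this assay, a number 9.6 percentage points lower (within the scatter) from compound 1 to compound 2 and a number 25 percentage points higher (beyond the scatter) from compound 3 to compound 4, 34.6 percentage points apart, beyond the scatter of two such steps. This shows that the outcome of the change is not the same across these two cores, but it does not show which structural difference between them is responsible, since the cores differ in more than one way and each is represented by a single pair.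

The compounds shown leave open whether a methoxy group or an amine in the same place would follow hydroxy on either core. They also leave open how the 4-chlorophenyl group that remains on compound 4 would respond to the same exchange.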